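The source may hold more compounds than are shown below. What is called first, only, known or untested is meant among the compounds shown, and "the series" means these compounds.

Of the compounds shown here, two from this series have been measured in an assay on cells for inhibition of sodium- and chloride-dependent glycine transporter 1 (Homo sapiens); on this read-out higher numbers stand for an effect only at larger amounts of compound and lower numbers for an effect already at smaller amounts. Compound 1, with the structure `COc1cc(C(F)(F)F)cc(C(F)(F)F)c1C(=O)NC1(c2ccccc2)CCCN(CC2CC2)C1`, gives 380 nM. Compound 2, with the structure `COc1cc(C(F)(F)F)cc(SC)c1C(=O)NC1(c2ccc(F)cc2)CCCN(C)C1`, gives 26 nM, the lowest of the two numbers; the gap from compound 1 to compound 2 lies beyond the usual scatter, so compound 2 acts at the smaller amount.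

Compound 3, with the structure `COc1cccc(C2(NC(=O)c3c(OC)cc(C(F)(F)F)cc3SC)CCCN(C)C2)c1`, has not been measured yet. It differs from compound 2 in one place: 3-methoxyphenyl in place of 4-fluorophenyl on a saturated ring carbon. The rest of the molecule, including the amide and the saturated ring with its methyl-bearing nitrogen, is unchanged.

Among the measured compounds shown here, no measured pair shows this exchange, so the expectation rests on compound 2 alone. The step from compound 2 to compound 3 is expected to be small, within or just beyond the scatter, and if anything toward a higher number: a 1.5-fold higher number from compound 2 to compound 3 (0.19 log units; within the scatter). Compound 3 is therefore estimated at 40 nM in this assay, with a range from 12 nM to 130 nM.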

Compound 3, half-maximal effective concentration: 110 nM
Beside the measured number, compound 3's estimate is 2.8-fold (0.44 log units) below it; the range from low to high includes it.
By their numbers in this assay, from the lowest: compound 2; then compound 3; then compound 1.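

In this assay the exchange of 4-fluorophenyl for 3-methoxyphenyl on the saturated ring carbon gives a 4.2-fold higher number from compound 2 to compound 3 (0.63 log units; beyond the scatter) and so shows that this position responds to the choice of substituted phenyl group. Compound 1 and compound 2 differ in several places at once, so their gap could not be tied to this position alone, whereas compound 2 and compound 3 differ here only. No measurement at hand explains the step, and the exchange changes both the substituent and its place on the phenyl ring.

Going by these compounds, it remains open whether the higher number follows the methoxy group itself or its place on the ring, a question that 4-methoxyphenyl and 3-fluorophenyl could separate. Also open, on these data alone, is how 4-chlorophenyl or an aminophenyl group would fare at this position.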